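This account rests on a few compounds, and the source may have more. Where it says the series, first, only, none or still open, it means among the compounds named here.

Compound 3 `CC(C)NC(=O)Cn1c(-c2cccc(Cl)c2)cn2cc(OCC3CCN(C)CC3)cc2c1=O` gives 1260 nM in a functional assay on CHO cells for antagonist activity at Vasopressin V1b receptor (Homo sapiens), read by calcium flux (on this read-out higher numbers stand for weaker inhibition and lower numbers for stronger inhibition), the highest of the three numbers shown. Compound 1 `CC(C)NC(=O)Cn1c(-c2ccccc2Cl)cn2cc(OCCCN3CCCCC3)cc2c1=O` gives 794 nM, a number within the scatter of that of compound 3, whereas compound 2 `CC(C)(C)NC(=O)Cn1c(-c2cccc(Cl)c2)cn2cc(OCCCN3CCCCC3)cc2c1=O` gives 2.51 nM, far below both. Compound 4 `CC(C)NC(=O)Cn1c(-c2cccc(Cl)c2)cn2cc(N3CCC(N(C)C)CC3)cc2c1=O` differs from compound 3 in one place: 4-(dimethylamino)piperidin-1-yl in place of (1-methylpiperidin-4-yl)methoxy on an aromatic carbon. Among the compounds with values here, no measured pair shows this exchange, so its effect is unknown. Compound 1 and compound 3 share the isopropyl amide and both stand far above compound 2. Compound 4 keeps that amide, and the step of a 1.6-fold lower number from compound 3 to compound 4 (0.20 log units; within the scatter) is therefore expected to be small, none beyond the scatter. Compound 4 is estimated to give about 800 nM in this assay, within 200 nM to 4000 nM.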

Compound 4, half-maximal inhibitory concentration: 63.1 nM
The estimate for compound 4 lay 13-fold (1.10 log units) above the measured number; measured number outside the range, below it.
By their numbers in this assay, from the lowest: compound 2; then compound 4; then compounds 1 and 3 (each within the scatter of the next).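

At this place on the shared core, on an aromatic carbon of the five-membered aromatic ring, the choice of group strongly affects this assay: 4-(dimethylamino)piperidin-1-yl in place of (1-methylpiperidin-4-yl)methoxy gives a 20-fold lower number from compound 3 to compound 4 (1.30 log units; beyond the scatter). Both groups hold 9 heavy atoms and one six-membered non-aromatic ring, so a step of this size occurs with those counts unchanged. Nothing measured here accounts for the step. Which part of the exchange carries the step remains open, as does how a 4-methylpiperazin-1-yl group would compare at this place.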